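Bicyclic diamine replaces pyrrolidine in a series at the limit

A few compounds are considered here, and "the series" means these few. Any claim that something is new, unique, unknown or untested is made for them only; others in the source may bear on it.

Of the compounds shown here, three have been measured in an assay on HEK293 cells for inhibition of transient receptor potential cation channel subfamily M member 8 (Homo sapiens), read by FLIPR and calcium flux (on this read-out lower numbers stand for stronger inhibition and higher numbers for weaker inhibition), and none of them has given a number. Compound 3 `CCN(C(=O)c1ccccc1OCc1ccccc1)C1CCNC1` sits at a limit of this assay, > 5000 nM. Compound 1 `CCN(C(=O)c1ccccc1OCc1ccccc1)[C@@H]1CC[C@H](N)C1` also stops at the limit of > 5000 nM. Compound 2 `CCN(C(=O)c1ccccc1OCc1ccccc1)C1CCNCC1` likewise reaches only the limit of > 5000 nM. The steps among these three, a step that the two limits leave unreadable from compound 1 to compound 2, a step that the two limits leave unreadable from compound 1 to compound 3 and a step that the two limits leave unreadable from compound 2 to compound 3, carry no readable size, as all three values sit at the limit of > 5000 nM in this assay, at which 3 of the 3 values shown sit.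

Compound 4 `O=C(c1ccccc1OCc1ccccc1)N1C[C@H]2CNC[C@H]2C1` carries a group of 8 heavy atoms (6 carbon, 2 nitrogen; 2 five-membered non-aromatic rings with 1 hetero atom each) in place of a group of 8 heavy atoms (6 carbon, 2 nitrogen; one five-membered non-aromatic ring with 1 hetero atom), on a carbonyl carbon. Among the measured compounds shown here, none of the measured steps bears on this change in a readable way; each of them is bounded at both ends by the limit of > 5000 nM in this assay, at which 3 of the 3 values shown sit. The step that the limit leaves unreadable from compound 3 to compound 4 expected in this assay is therefore read as none beyond the scatter, with no direction that the data can support. Compound 4 is expected to come out near 8000 nM, in a range from 2000 nM to 30000 nM, and the most likely outcome is that this assay again reports only a limit for compound 4.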

Compound 4, antagonist equilibrium constant: > 10000 nM
Compound 4 gave a limit, no number; the forecaster's own chance of this, stated with the estimate: 80%; at least 1.2-fold (0.09 log units) between middle value and limit.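

In this assay compound 4 gives only a limit, > 10000 nM. Compound 3 also gives only a limit, > 5000 nM, and no step can be read between compound 3 and compound 4. The compounds shown leave open how strongly any of the four inhibits, and whether the group with 2 five-membered non-aromatic rings differs at all from the group with one.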